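Replacing the 2-fluorophenyl group of compound 2

This account rests on a few compounds, and the source may have more. Where it says the series, first, only, none or still open, it means among the compounds named here.

Compound 1 `Cc1cc(-c2ccccc2F)cc(C)c1Oc1cc(N)nc(Nc2ccc(C#N)cc2)n1` gives 29300 nM 
Compound 2 `Cc1cc(-c2ccccc2F)ccc1Oc1cc(N)nc(Nc2ccc(C#N)cc2)n1` gives 29500 nM 

Within the data shown here, in a toxicity assay on MT4 cells (Homo sapiens) for cytotoxicity, read by MTT assay (a lower number here means that less compound is tolerated, a higher number that more compound is tolerated), compound 2 reads 29500 nM and stands level with compound 1 on the only two numbers available. Among the measured compounds shown here, the single measured step, hydrogen in place of methyl on an aromatic carbon, is a 1.0-fold higher number from compound 1 to compound 2 (0.00 log units; within the scatter) and says little beyond that. Compound 3 `Cc1cc(-c2cccc(C#N)c2)ccc1Oc1cc(N)nc(Nc2ccc(C#N)cc2)n1` keeps the core of compound 2 and changes one group: 3-cyanophenyl in place of 2-fluorophenyl on an aromatic carbon with 3-cyanophenyl in place of 2-fluorophenyl. For the measured compounds named here, no measured step touches this group, so the expectation rests indirectly on that one step, which concerns a different place. No move beyond the scatter is expected, and the estimated change is a 1.3-fold lower number from compound 2 to compound 3 (0.13 log units; within the scatter) in a slightly lower direction. Compound 3 is expected at 22000 nM (range 8000 nM to 50000 nM).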

Compound 3, half-maximal cytotoxic concentration: 27400 nM
The estimate for compound 3 lay 1.2-fold (0.10 log units) below the measured number, within the range that was stated.
By their numbers in this assay, from the lowest: compounds 3, 1 and 2 (each within the scatter of the next).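

In this assay, among these compounds, the exchange of 2-fluorophenyl for 3-cyanophenyl gives a 1.1-fold lower number from compound 2 to compound 3 (0.03 log units; within the scatter), the first reading at this position; the earlier step concerned a methyl group elsewhere on the same ring. The entering group brings a triple bond and a hydrogen-bond acceptor that the leaving group lacks, yet the step stays within the scatter, so this pair shows no sensitivity of the number to that exchange. No measurement available here bears on the reason for this result.

The pair changes the substituent and its place on the phenyl ring together, so those two contributions cannot be told apart. Also open, on these data alone, is how the number responds at this position to a group other than a substituted phenyl, such as a carboxylic acid or a simple amine.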